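The source may hold more compounds than are shown below. What is called first, only, known or untested is meant among the compounds shown, and "the series" means these compounds.

Working notes on the series. The common core is seen in compound 1 `Cc1cc(C(=O)NCc2ccccn2)nn1Cc1cc(Cl)ccc1OCc1ccccc1`. Compound 2 `Cc1cc(NC(=O)CC2CCCCC2)nn1Cc1cc(Cl)ccc1OCc1ccccc1` and compound 3 `Cc1cc(NC(=O)C2CCOC2)nn1Cc1cc(Cl)ccc1OCc1ccccc1` differ from compound 1 in the amide portion, and from each other in the group on the carbonyl carbon. In an assay on CHO-K1 cells for displacement of a labelled ligand from prostaglandin E2 receptor EP1 subtype (Homo sapiens) (on this read-out lower numbers stand for stronger inhibition and higher numbers for weaker inhibition), compound 1 gives 25.1 nM, compound 2 gives 6.31 nM and compound 3 gives 39.8 nM. Compound 3 thus stands with the highest number of the three; its nearest neighbour is compound 1, with a 1.6-fold higher number from compound 1 to compound 3 (0.20 log units; within the scatter), while a 6.3-fold higher number from compound 2 to compound 3 (0.80 log units; beyond the scatter) lies beyond the scatter.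

Compound 4 `Cc1cc(NC(=O)c2ccccc2)nn1Cc1cc(Cl)ccc1OCc1ccccc1` differs from compound 3 in one place: phenyl in place of oxolan-3-yl on a carbonyl carbon. The step that bears most directly on it is the exchange on the same carbonyl carbon, from compound 2 to compound 3, a modest move beyond the scatter; a 4.0-fold lower number from compound 1 to compound 2 (0.60 log units; beyond the scatter) shows a change of similar size elsewhere in the amide. Among the compounds with values here, neither step involves phenyl, so the direction is uncertain and rests on compound 3 holding the highest number measured so far. A modest move towards lower numbers is expected, a 2.5-fold lower number from compound 3 to compound 4 (0.40 log units; beyond the scatter), with the range kept wide. Compound 4 is therefore estimated at 16 nM, between 4 nM and 63 nM.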

Compound 4, half-maximal inhibitory concentration: 15.9 nM
Compound 4: the middle estimate sits 1.0-fold (0.00 log units) above what was measured; the range from low to high includes it.
By their numbers in this assay, from the lowest: compound 2; then compounds 4, 1 and 3 (each within the scatter of the next, the first and the last beyond it).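

In this assay the carbonyl carbon now carries three groups whose listed steps all lie beyond the scatter: phenyl in place of oxolan-3-yl gives a modest change (a 2.5-fold lower number from compound 3 to compound 4 (0.40 log units; beyond the scatter)), and phenyl in place of cyclohexylmethyl gives a modest change in the other direction (a 2.5-fold higher number from compound 2 to compound 4 (0.40 log units; beyond the scatter)), so phenyl takes the middle place of the three on this carbon. On the aromatic carbon, benzamido and ((pyridin-2-yl)methyl)carbamoyl cannot be told apart (a 1.6-fold lower number from compound 1 to compound 4 (0.20 log units; within the scatter)), so this pair shows no separation between these two amide forms, although they differ in the group as a whole. No measurement at hand accounts for any of these differences.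

Phenyl and cyclohexylmethyl differ both in the ring and in the methylene that joins it to the carbonyl carbon, so it remains open which of the two matters, and cyclohexyl or benzyl on the same carbon would separate them. Also open, as far as these compounds go, is how the benzoyl ring tolerates further groups, such as a carboxylic acid, an amine or a methoxy group, and whether a longer chain on the carbonyl carbon follows the same order.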